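Cyclopropylcarbamoyl in Place of Hydroxyethyl: an Expected Potency

The compounds below may be only part of what the source reports. "The series", "measured", "known", "first", "only" and "open" are said of these compounds alone.

Compound 1 `Cn1ncc(Cl)c1-c1cc(C(=O)N[C@@H]2CN[C@H](CCCO)C[C@H]2c2ccc(Cl)c(Cl)c2)oc1Cl` is measured in a functional assay on LNCaP cells (Homo sapiens) for antiproliferative activity (on this read-out higher numbers stand for weaker inhibition and lower numbers for stronger inhibition), at 210 nM. Among the three compounds with numbers, compound 1 holds the second highest value: compound 3 `CNC(=O)C[C@@H]1C[C@@H](c2ccc(F)c(F)c2)[C@H](NC(=O)c2cc(-c3c(Cl)cnn3C)c(Cl)o2)CN1` gives 50 nM, a lower number beyond the scatter, while compound 2 `Cn1ncc(Cl)c1-c1cc(C(=O)N[C@@H]2CN[C@H](CCN3CCCCC3)C[C@H]2c2ccc(Cl)c(Cl)c2)oc1Cl` gives 1780 nM. Among the measured compounds shown here, the one single-point step available, an 8.5-fold higher number from compound 1 to compound 2 (0.93 log units; beyond the scatter), shows that extending the side chain into a basic ring weakened inhibition modestly.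

Compound 4 `Cn1ncc(Cl)c1-c1cc(C(=O)N[C@@H]2CN[C@H](CC(=O)NC3CC3)C[C@H]2c2ccc(Cl)c(Cl)c2)oc1Cl` has not yet been measured in this assay. It differs from compound 1 by cyclopropylcarbamoyl in place of 2-hydroxyethyl on a saturated chain carbon bound to a saturated ring carbon. For the measured compounds named here, no measured step isolates this change. Compound 3, which also carries a carbamoyl-bearing chain but on a different aryl ring, gives the lowest number shown, so a carbamoyl chain of this kind coexists with strong inhibition; the step from compound 1 to compound 2 warns that chain changes can also cost potency. Compound 4 is therefore expected to show a small improvement, a 1.9-fold lower number from compound 1 to compound 4 (0.28 log units; within the scatter), though within a broad band. The estimate for compound 4 is 110 nM, expected to fall between 30 nM and 400 nM.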

Compound 4, half-maximal inhibitory concentration: 190 nM
Compound 4: middle estimate off by 1.7-fold (0.24 log units), on the low side; the measured number falls inside the stated range.
By their numbers in this assay, from the lowest: compound 3; then compounds 4 and 1 (each within the scatter of the next); then compound 2.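

In this assay, the step for cyclopropylcarbamoyl in place of 2-hydroxyethyl on a saturated chain carbon bound to a saturated ring carbon is a 1.1-fold lower number from compound 1 to compound 4 (0.04 log units; within the scatter), so this position takes the amide with its three-membered ring without a difference beyond the scatter. The other step, a 9.4-fold lower number from compound 2 to compound 4 (0.97 log units; beyond the scatter), shows that the amide, like the 3-hydroxypropyl chain of compound 1, stands well apart from the piperidine-bearing chain of compound 2. Nothing measured here accounts for this tolerance.

On these data alone, whether a carboxylic acid, a primary amine or a longer chain ending in the same amide would keep the number in this range remains open. Compound 3 differs from compound 4 in more than one place, so the source of its lower number stays unresolved.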